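Cyclohexylamino analogue in the nitro trifluoromethyl series: cytotoxicity

The source may hold more compounds than are shown below. What is called first, only, known or untested is meant among the compounds shown, and "the series" means these compounds.

The series shares the core seen in compound 1 `O=c1cc(NCc2ccccc2)sc2c([N+](=O)[O-])cc(C(F)(F)F)cc12` and compound 2 `COc1ccc(CN(C)c2cc(=O)c3cc(C(F)(F)F)cc([N+](=O)[O-])c3s2)cc1OC`. In an ADME assay on Vero cells (Chlorocebus sabaeus) for cytotoxicity, read by MTT assay, with a stated time of 48 h (on this read-out higher numbers stand for weaker inhibition and lower numbers for stronger inhibition), compound 1 gives > 64 ug/mL, which is a limit of the assay and not a number. In this assay compound 2 likewise gives > 64 ug/mL, also a limit. Going by the values given here, compound 1 therefore stands at the limit of > 64 ug/mL in this assay, at which 2 of the 2 values shown sit; no measured step between compounds is available, and the two values show only that both sit at that limit.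

Compound 3 `O=c1cc(NC2CCCCC2)sc2c([N+](=O)[O-])cc(C(F)(F)F)cc12` is not yet measured in this assay. Its difference from compound 1 is cyclohexyl in place of benzyl on a nitrogen on an aromatic ring. The step from compound 1 to compound 3 is expected to be a step that the limit leaves unreadable from compound 1 to compound 3, that is none beyond the scatter. In this assay compound 3 is estimated at 80 ug/mL, within a range of 40 ug/mL to 200 ug/mL, and is expected most likely to be reported again as a limit.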

Compound 3, half-maximal inhibitory concentration: > 64 ug/mL
Compound 3 gave a limit, no number (the forecaster's own chance of this, stated with the estimate: 75%); the middle value lies beyond the limit too.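

In this assay compound 3 gives > 64 ug/mL, a limit and not a number, so no step from compound 1 to compound 3 can be read: the limit of > 64 ug/mL in this assay, at which 3 of the 3 values shown sit.

The compounds shown leave open whether benzylamino and cyclohexylamino differ at all in this assay, and at what concentration any of the three reaches half-maximal inhibition.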